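Replacing 3-fluorophenyl with 2,5-dimethylphenyl in a small inhibitor series

The compounds below may be only part of what the source reports. "The series", "measured", "known", "first", "only" and "open" are said of these compounds alone.

Three measured compounds share one core and differ only in the aromatic group on a saturated chain carbon bound to an amide-type nitrogen. In a functional assay on Jurkat cells (Homo sapiens) (a lower number here means a stronger inhibitor, a higher number a weaker inhibitor), compound 1 `C[C@H](NC(=O)C(=O)NCc1ccc(Cl)cc1)C(=O)N[C@@H](CC(=O)O)C(=O)COc1c(F)c(F)cc(F)c1F` gives 8.4 nM with 4-chlorophenyl in that place. Compound 2 `Cc1ccccc1CNC(=O)C(=O)N[C@@H](C)C(=O)N[C@@H](CC(=O)O)C(=O)COc1c(F)c(F)cc(F)c1F` gives 52 nM with 2-methylphenyl there. Compound 3 `C[C@H](NC(=O)C(=O)NCc1cccc(F)c1)C(=O)N[C@@H](CC(=O)O)C(=O)COc1c(F)c(F)cc(F)c1F` gives 106 nM with 3-fluorophenyl, the highest number of the three and so the weakest inhibitor so far.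

For the measured compounds named here, compound 4 `Cc1ccc(C)c(CNC(=O)C(=O)N[C@@H](C)C(=O)N[C@@H](CC(=O)O)C(=O)COc2c(F)c(F)cc(F)c2F)c1` changes only this group, and the difference reads 2,5-dimethylphenyl in place of 3-fluorophenyl on a saturated chain carbon bound to an amide-type nitrogen in full. Its closest measured relative is compound 2, which also carries a methyl-substituted phenyl. The most relevant measurement is therefore the modest step of a 2.0-fold higher number from compound 2 to compound 3 (0.31 log units; beyond the scatter) and, read backwards, it suggests some improvement for compound 4. The larger steps of a 6.2-fold higher number from compound 1 to compound 2 (0.79 log units; beyond the scatter) and a 13-fold higher number from compound 1 to compound 3 (1.10 log units; beyond the scatter) show that this position can shift the number considerably. Going by the values given here, no measured compound carries 2,5-dimethylphenyl, so the second methyl group remains untested. A modest drop is expected, with the estimated step being a 2.7-fold lower number from compound 3 to compound 4 (0.42 log units; beyond the scatter) on these grounds. For compound 4 the estimated value is 40 nM with an expected range from 12 nM to 130 nM in this assay once measured.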

Compound 4, half-maximal inhibitory concentration: 11 nM
Beside the measured number, compound 4's estimate is 3.6-fold (0.56 log units) above it, outside the stated range (below it).
By their numbers in this assay, from the lowest: compounds 1 and 4 (each within the scatter of the next); then compound 2; then compound 3.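

Adding one methyl group to the ring of compound 2 gives a 4.7-fold lower number from compound 2 to compound 4 (0.67 log units; beyond the scatter) in this assay, so this small change at an aromatic carbon matters more than the earlier comparisons could reveal, as none of them isolated a single added methyl group. The full exchange of 3-fluorophenyl for 2,5-dimethylphenyl gives a 9.6-fold lower number from compound 3 to compound 4 (0.98 log units; beyond the scatter) and is the widest change among the steps to the new compound, showing that a ring with only carbon substituents can perform very well at this position. The remaining comparison, a 1.3-fold higher number from compound 1 to compound 4 (0.12 log units; within the scatter) and within the usual scatter, shows that among these four compounds a chlorine on the ring is not needed to reach this low range, though nothing shown explains why the second methyl group has so much effect.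

The compounds shown leave open whether the second methyl group would have the same effect without the first, and whether a larger alkyl group such as ethyl or isopropyl would extend the trend. They also leave open how a methoxy group, an amine or a carboxylic acid on the ring would fare in this assay.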